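Bromo for Fluoro on an Unreadable Cytotoxicity Series

This account rests on a few compounds, and the source may have more. Where it says the series, first, only, none or still open, it means among the compounds named here.

Of the compounds shown here, three sharing one core have been tested in a toxicity assay on NIH3T3 cells (Mus musculus) for cytotoxicity, read by resazurin assay; a lower number here means that less compound is needed, a higher number that more compound is needed for the effect. Compound 1 `COC(=O)c1ccc(NCc2cncn2Cc2ccc(C#N)cc2)cc1-c1ccccc1` carries a 4-cyanophenyl on a saturated chain carbon bound to an aromatic nitrogen. In this assay compound 1 gives > 10000 nM, which is a limit of the assay and not a number. Compound 2 `COC(=O)c1ccc(NCc2cncn2Cc2cccc(C#N)c2)cc1-c1ccccc1` has 3-cyanophenyl in place of 4-cyanophenyl. In this assay compound 2 gives > 10000 nM, again a limit. Compound 3 `COC(=O)c1ccc(NCc2cncn2Cc2cccc(F)c2)cc1-c1ccccc1` has 3-fluorophenyl in place of 4-cyanophenyl. In this assay compound 3 gives > 1000 nM, also a limit. So compound 3 stands on a limit, as do the other two values. The steps a step that the two limits leave unreadable from compound 1 to compound 2, a step that the two limits leave unreadable from compound 1 to compound 3 and a step that the two limits leave unreadable from compound 2 to compound 3 cannot be sized because the limit of > 10000 nM in this assay, at which 2 of the 3 values shown sit, holds two of the values and the limit of > 1000 nM in this assay, at which 1 of the 3 values shown sits, the third.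

Compound 4 `COC(=O)c1ccc(NCc2cncn2Cc2cccc(Br)c2)cc1-c1ccccc1` differs from compound 3 by bromo in place of fluoro on an aromatic carbon. For the measured compounds named here, no measured step involves a bromo group, and none has a readable size, so nothing suggests a shift beyond the scatter. Compound 4 is therefore expected to give roughly 5000 nM, within 1000 nM to 30000 nM, most likely again as a limit. The expected step is a step that the limit leaves unreadable from compound 3 to compound 4.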

Compound 4, half-maximal effective concentration: > 10000 nM
Compound 4 gave a limit, no number; the forecaster's own chance of this, stated with the estimate: 75%; middle value at least 2.0-fold (0.30 log units) away from the limit.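

In this assay compound 4 gives > 10000 nM, which is a limit of the assay and not a number, so its steps from compound 1, compound 2 and compound 3 cannot be read. On these data alone, what stays open is the concentration at which any of the four compounds has its effect on the cells, and whether exchanging cyano, fluoro and bromo changes it.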